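This account rests on a few compounds, and the source may have more. Where it says the series, first, only, none or still open, it means among the compounds named here.

In a functional assay on HEL cells (Homo sapiens) for cytotoxicity (a higher number here means that more compound is tolerated, a lower number that less compound is tolerated), compound 2 `C=CCCCCCCc1cc2cn([C@H]3C[C@H](O)[C@@H](CO)O3)c(=O)nc2o1` stands at > 200000 nM, which is a limit and not a number. Compound 1 `CCCCCCCc1cc2cn([C@H]3C[C@H](O)[C@@H](CO)O3)c(=O)nc2o1` also gives only a limit, > 50000 nM. No numerical reading is therefore available for either measured compound.

The next change leads to compound 3 `C#CCCCc1cc2cn([C@H]3C[C@H](O)[C@@H](CO)O3)c(=O)nc2o1`. The difference is ethynyl in place of pent-4-en-1-yl on a saturated chain carbon, three bonds along the chain from an aromatic carbon.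

For the measured compounds named here, only one measured step bears on this change, a step that the two limits leave unreadable from compound 1 to compound 2. Both of its ends are limits, so it offers no size to carry over, and neither direction is supported in this assay. The expected step, with no shift beyond the scatter anticipated, is a number no higher from compound 2 to compound 3 (the limit leaves the size open). Another limit is the most likely report. The estimate for compound 3 is 200000 nM, with an expected range of 50000 nM to 400000 nM.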

Compound 3, half-maximal cytotoxic concentration: > 200000 nM
Compound 3 gave a limit, no number (the forecaster's own chance of this, stated with the estimate: 75%); the middle value lies on the limit itself.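

In this assay compound 3 gives > 200000 nM, a limit and not a number. For the compounds shown here, no step among compound 1, compound 2 and compound 3 can be read. The compounds shown leave open what half-maximal cytotoxic concentration any of the three actually has, and whether the chain changes shift it.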